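This account rests on a few compounds, and the source may have more. Where it says the series, first, only, none or still open, it means among the compounds named here.

Measured in a functional assay on U-373MG ATCC cells (Homo sapiens) for inhibition, read by MTT assay; a higher number here means a weaker inhibitor, a lower number a stronger inhibitor:
Compound 1 `CCCCCCCCCCCC(=O)OC1=C(CC=C(C)C)C(=O)c2ccccc2C1=O`: 31000 nM
Compound 2 `CCCCCCCCCCCCCC(=O)OC1=C(CC=C(C)C)C(=O)c2ccccc2C1=O`: > 100000 nM (a limit, not a number)

Compound 2 has no exact position on this scale, and its reading is the limit of > 100000 nM in this assay, at which 1 of the 2 values shown sits. Compound 3 `CCCCCCCCCCCCCCCC(=O)OC1=C(CC=C(C)C)C(=O)c2ccccc2C1=O` has not yet been measured. It differs from compound 2 by ethyl in place of hydrogen on a saturated chain carbon, ten or more bonds along the chain from a carbonyl carbon, which is ethyl in place of hydrogen on a saturated chain carbon, ten or more bonds along the chain from a carbonyl carbon.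

Among the compounds with values here, only one measured step bears on this change, and it is the same change: an at least 3.2-fold higher number from compound 1 to compound 2 (0.50 log units; beyond the scatter). That step lies beyond the scatter and runs toward weaker inhibition, so a further move in the same direction is expected, of modest size or more. The expected step is a step that the limit leaves unreadable from compound 2 to compound 3. A reading reported only as a limit is also likely. Compound 3 is estimated at 180000 nM, with an expected range of 70000 nM to 500000 nM.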

Compound 3, half-maximal inhibitory concentration: 54000 nM
For compound 3 the middle estimate is 3.3-fold (0.52 log units) above the measured one, outside the stated range (below it).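

In this assay, the same ethyl in place of hydrogen, at the same place on the chain, does not repeat the earlier move toward weaker inhibition; this time it gives an at least 1.8-fold lower number from compound 2 to compound 3 (0.26 log units; that floor lies within the scatter). Going by these compounds, the reading for compound 2 is a limit and not a number, so the true size of this step stays unknown: the limit of > 100000 nM in this assay, at which 1 of the 3 values shown sits. Taken as a whole, the full lengthening of the chain gives a 1.7-fold higher number from compound 1 to compound 3 (0.24 log units; within the scatter), so the added length alone does not separate these two esters.

Where compound 2 truly sits on this scale remains open. So does whether a longer chain, or an amine or a carboxylic acid carried on the chain, would move the reading beyond the scatter.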